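Benzyl in place of (4-methylphenyl)sulfonyl: cytotoxicity notes

This account rests on a few compounds, and the source may have more. Where it says the series, first, only, none or still open, it means among the compounds named here.

Among the measured compounds shown here, compound 2 `Cc1ccc(S(=O)(=O)O[C@@H]2CO[C@H]3[C@@H]2OCc2nc4c(Br)c(C)c(Br)cc4n23)cc1` is the only member of the pair with a numerical reading in an ADME assay on HEp-2 cells (Homo sapiens) for cytotoxicity, read by MTT assay, with a stated time of 60 h (on this read-out higher numbers stand for lower toxicity in this test and lower numbers for higher toxicity in this test), where compound 2 gives 8940 nM. Compound 1 `O[C@@H]1CO[C@H]2[C@@H]1OCc1nc3cc(Br)cc(Cl)c3n12` returns only a limit in this assay, reported as > 800000 nM. Compound 3 `Cc1c(Br)cc2c(nc3n2[C@H]2OC[C@@H](OCc4ccccc4)[C@H]2OC3)c1Br` differs from compound 2 by benzyl in place of (4-methylphenyl)sulfonyl on an oxygen on a saturated carbon. For the measured compounds named here, no measured step between compounds covers this change, so the expectation rests on compound 2 alone. A step of modest size toward lower toxicity, a 1.7-fold higher number from compound 2 to compound 3 (0.22 log units; within the scatter), is expected for compound 3. In this assay compound 3 is estimated at 15000 nM, with a range from 4000 nM to 60000 nM.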

Compound 3, half-maximal cytotoxic concentration: 25600 nM
For compound 3 the middle estimate is 1.7-fold (0.23 log units) below the measured one; the range from low to high includes it.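

In this assay, among the compounds shown here, replacing (4-methylphenyl)sulfonyl with benzyl on this oxygen gives a 2.9-fold higher number from compound 2 to compound 3 (0.46 log units; beyond the scatter) and provides the first measured step at this position. Both groups give numerical readings, so the sulfonyl link is not required for measurable cytotoxicity in this test. Nothing shown bears on why the number moves.

On these data alone, it remains open whether the step follows from losing the sulfonyl link or from changing the group attached to the aromatic ring. As far as these compounds go, the outcome with an amine or a carboxylic acid carried on a longer chain at this oxygen also remains open.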